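Adding a Second Chlorine to the Phenoxy Ring

The compounds below may be only part of what the source reports. "The series", "measured", "known", "first", "only" and "open" are said of these compounds alone.

Compound 1 `O=C(COc1ccc(Cl)cc1)NNC(=S)NCc1ccc(-c2ccccc2)cc1` and compound 2 `O=C(COc1cccc(Cl)c1)NNC(=S)NCc1ccc(-c2ccccc2)cc1` share the same core and differ only in where a single chlorine sits on the ring attached to the oxygen. In an assay on isolated protein for inhibition of A disintegrin and metalloproteinase with thrombospondin motifs 5 (Homo sapiens), read by spectrophotometry, with stated times of 10 min and 3 h (a higher number here means a weaker inhibitor, a lower number a stronger inhibitor), compound 1 gives 1200 nM, and compound 2 gives 2100 nM. The step of a 1.8-fold higher number from compound 1 to compound 2 (0.24 log units; within the scatter) shows that moving the chlorine produced no difference worth trusting. Of the two measured numbers, compound 2 carries the higher one, but its gap to compound 1 lies within the scatter, so neither compound can be called the weaker inhibitor.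

Compound 3 `O=C(COc1ccc(Cl)cc1Cl)NNC(=S)NCc1ccc(-c2ccccc2)cc1` has not yet been measured. Its change from compound 2 is 2,4-dichlorophenyl in place of 3-chlorophenyl on an oxygen on a saturated carbon. Within the data shown here, the only measured step that bears on this change is a 1.8-fold higher number from compound 1 to compound 2 (0.24 log units; within the scatter), and it concerns only the position of one chlorine; no measured pair shows what a second chlorine does. Among the measured compounds shown here, with the one relevant step inside the scatter, no step beyond the scatter is expected in this assay. Compound 3 is expected to give 1500 nM, within a range from 500 nM to 4500 nM. The expected step of a 1.4-fold lower number from compound 2 to compound 3 (0.15 log units; within the scatter) is accordingly small in either direction.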

Compound 3, half-maximal inhibitory concentration: 1200 nM
Beside the measured number, compound 3's estimate is 1.3-fold (0.10 log units) above it; measured number inside the range.
By their numbers in this assay, from the lowest: compounds 1, 3 and 2 (each within the scatter of the next).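

Among these compounds, the new comparison is the first to show what a second chlorine does on this ring: in this assay, chloro in place of hydrogen on an aromatic carbon gives no change at the digits printed from compound 1 to compound 3 (within the scatter) and so leaves no difference that can be trusted. Replacing the 3-chlorophenyl group with the 2,4-dichlorophenyl group gives a 1.8-fold lower number from compound 2 to compound 3 (0.24 log units; within the scatter) and also stays inside the scatter, so the three chlorinated groups cannot be told apart by this measurement. Nothing available offers a reason why the added chlorine leaves the result so flat.

The compounds shown leave open whether a plain phenyl group with no chlorine at all would read the same, and whether this flat picture would hold for a group other than chlorine on the ring, such as a methoxy group or a carboxylic acid. They also leave open whether a longer chain in place of the saturated carbon on the oxygen would shift the number beyond the scatter.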